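The source may report more compounds than this note shows. Statements on the series, on what has been measured and on what is new or still open speak of the compounds shown alone.

Measured compounds in a functional assay on BXPC-3 cells (Homo sapiens) for cytotoxicity, read by fluorescence, with a stated time of 48 h; a lower number here means that less compound is needed, a higher number that more compound is needed for the effect:
- compound 1 `CC(C)=CCC/C(C)=C/CC/C(C)=C/CSC[C@H](NC(=O)CCCCCN1CCN(C)CC1)C(=O)NC1CC1`: 6300 nM
- compound 2 `CC(C)=CCC/C(C)=C/CC/C(C)=C/CSC[C@H](NC(=O)CCCCCN1CCN(C)CC1)C(=O)N1CCCC1`: 3200 nM
- compound 3 `CC(C)=CCC/C(C)=C/CC/C(C)=C/CSC[C@H](NC(=O)CCCCCN1CCCC1)C(=O)NC1CC1`: > 20000 nM

The value for compound 3 is a limit of the assay, not a number. The step of an at least 3.1-fold higher number from compound 1 to compound 3 (0.50 log units; beyond the scatter) is therefore open-ended due to the limit of > 20000 nM in this assay, at which 1 of the 3 values shown sits; the cores of compound 1 and compound 3 differ as pyrrolidin-1-yl in place of 4-methylpiperazin-1-yl on a saturated chain carbon, five bonds along the chain from a carbonyl carbon.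

Compound 4 `CC(C)=CCC/C(C)=C/CC/C(C)=C/CSC[C@H](NC(=O)CCCCCN1CCCC1)C(=O)N1CCCC1` is not yet measured. It differs from compound 3 as pyrrolidin-1-yl in place of cyclopropylamino on a carbonyl carbon, and compound 2 differs from compound 1 as pyrrolidin-1-yl in place of cyclopropylamino on a carbonyl carbon; the place given for both is the same word for word, so this is the same change. Among the compounds with values here, its one measured instance gave a 2.0-fold lower number from compound 1 to compound 2 (0.29 log units; within the scatter) in this assay. The step from compound 3 to compound 4 is expected to be of similar size, a number no higher from compound 3 to compound 4 (the limit leaves the size open), resting on that single instance. Compound 4 is accordingly estimated at 20000 nM, between 8000 nM and 50000 nM, with a fair chance that this assay again reports only a limit.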

Compound 4, half-maximal effective concentration: 6500 nM
For compound 4 the middle estimate is 3.1-fold (0.49 log units) above the measured one; the measured number lies below the stated range.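

In this assay compound 3 stands at > 20000 nM, which is a limit of the assay. Pyrrolidin-1-yl in place of cyclopropylamino on a carbonyl carbon gives an at least 3.0-fold lower number from compound 3 to compound 4 (0.48 log units; beyond the scatter), but whether this differs in size from the earlier instance stays unsettled: the same change on two cores in this assay, a 2.0-fold lower number (0.29 log units; within the scatter) from compound 1 to compound 2 and an at least 3.0-fold lower number (0.48 log units; beyond the scatter) from compound 3 to compound 4; the limit leaves it open whether they differ. Pyrrolidin-1-yl in place of 4-methylpiperazin-1-yl on a saturated chain carbon gives a 2.0-fold higher number from compound 2 to compound 4 (0.31 log units; beyond the scatter), so this change points the same way on both cores, though the size of any gap between the instances cannot be read: the same change on two cores in this assay, an at least 3.1-fold higher number (0.50 log units; beyond the scatter) from compound 1 to compound 3 and a 2.0-fold higher number (0.31 log units; beyond the scatter) from compound 2 to compound 4; the limit leaves it open whether they differ.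

Two cores per change give no rule for the wider series. Going by these compounds, it remains open how morpholin-4-yl or dimethylamino in place of 4-methylpiperazin-1-yl, or an acyclic amine such as diethylamino in place of pyrrolidin-1-yl on the carbonyl carbon, would read.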